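Methoxy-to-cyano swap on the benzyl group, mouse dosing

This account rests on a few compounds, and the source may have more. Where it says the series, first, only, none or still open, it means among the compounds named here.

Measured so far:
compound 1 `COc1ccc(Cn2cc(CO/N=C/c3c(-c4ccccc4)nc4c(C)cccn34)nn2)cc1` — 100 mg/kg
compound 2 `COc1ccc(Cn2cc(CO/N=C/c3c(-c4ccc(C)cc4)nc4ccc(Br)cn34)nn2)cc1` — 40 mg/kg
compound 3 `Cc1ccc(-c2nc3ccc(Br)cn3c2/C=N/OCc2cn(Cc3ccc(C#N)cc3)nn2)cc1` — 40 mg/kg

In a functional assay on the whole organism (strain NMRI) with Mus musculus as the target, with a stated time of 4 h (on this read-out higher numbers stand for an effect only at larger amounts of compound and lower numbers for an effect already at smaller amounts), compound 1 gives 100 mg/kg, the highest number of the three. Compound 2 gives 40 mg/kg and compound 3 gives 40 mg/kg; each of these lies below compound 1 by more than the scatter. The difference between the core of compound 1 and the core of compound 2 is not broken down here. Compound 2 and compound 3 differ by one change, (cyano in place of methoxy on an aromatic carbon), and on that change no change at the digits printed from compound 2 to compound 3 (within the scatter).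

Compound 4 `Cc1cccn2c(/C=N/OCc3cn(Cc4ccc(C#N)cc4)nn3)c(-c3ccccc3)nc12` is not yet measured. It carries the same change as the pair above, (cyano in place of methoxy on an aromatic carbon), on the core of compound 1. The step from compound 1 to compound 4 is expected to be no change at the digits printed from compound 1 to compound 4 (within the scatter), because no change at the digits printed from compound 2 to compound 3 (within the scatter) showed this change leaving the read-out flat on the other core; that single pair is the only support. Compound 4 is therefore estimated at 100 mg/kg, with a range from 50 mg/kg to 200 mg/kg.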

Compound 4, minimum effective dose: 40 mg/kg
Beside the measured number, compound 4's estimate is 2.5-fold (0.40 log units) above it; measured number outside the range, below it.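

In this assay, the change from 4-methoxybenzyl to 4-cyanobenzyl on the core of compound 1 gives a 2.5-fold lower number from compound 1 to compound 4 (0.40 log units; beyond the scatter). Set beside the same change on the other core, this step does not differ from the earlier one by more than the scatter, so the two cores give no measured sign that the change behaves differently from one to the other: the same change on two cores in this assay, no change at the digits printed (within the scatter) from compound 2 to compound 3 and a 2.5-fold lower number (0.40 log units; beyond the scatter) from compound 1 to compound 4, 2.5-fold (0.40 log units) apart, within the scatter of two such steps. Two pairs neither prove that the step is the same on both cores nor fix its size on any further core.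

Only methoxy and cyano appear at this place on the benzyl group. On these data alone, a chlorine, an amine or a carboxylic acid there remains open, as does a longer chain in place of the benzyl group.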